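From Methyl to Butyl on the Shared Core

The source may report more compounds than this note shows. Statements on the series, on what has been measured and on what is new or still open speak of the compounds shown alone.

Compound 1: `COc1ccc(NC(=O)/C=C/c2ccc(C(C)(C)C)cc2)cc1O`, 30 nM in a functional assay on CHO cells for inhibition of transient receptor potential cation channel subfamily V member 1 (Homo sapiens); a lower number here means a stronger inhibitor, a higher number a weaker inhibitor
Compound 2: `O=C(/C=C/c1ccccc1)Nc1ccc2c(c1)OCCO2`, > 4000 nM in this assay
Compound 3: `Cc1ccc(/C=C/C(=O)Nc2ccc3c(c2)OCCO3)cc1`, 210 nM in this assay

Of the two compounds that return a number in this assay, compound 3 carries the higher one. For the measured compounds named here, compound 1 sits at 30 nM, a gap from compound 3 that lies beyond the usual scatter, though the two differ in more than one place and no single step joins them. Compound 2 gives only > 4000 nM, which is a limit of the assay and not a number (the limit of > 4000 nM in this assay, at which 1 of the 3 values shown sits).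

Compound 4, `CCCCc1ccc(/C=C/C(=O)Nc2ccc3c(c2)OCCO3)cc1`, has not been measured. It differs from compound 3 by propyl in place of hydrogen on a saturated chain carbon bound to an aromatic carbon; cut one bond further out, the same difference reads methyl to butyl. Going by the values given here, the one measured step that bears on it is an at least 19-fold lower number from compound 2 to compound 3 (1.27 log units; beyond the scatter), a large step in which a methyl entered the same region that the propyl of compound 4 now extends. Lengthening the chain is expected to move the number in the same direction, but by a smaller step than the first methyl did. In this assay compound 4 is therefore estimated at 100 nM, expected to fall between 30 nM and 350 nM, an expected step of a 2.1-fold lower number from compound 3 to compound 4 (0.32 log units; beyond the scatter).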

Compound 4, half-maximal inhibitory concentration: 360 nM
For compound 4 the middle estimate is 3.6-fold (0.56 log units) below the measured one; measured number above the stated range.
By their numbers in this assay, from the lowest: compound 1; then compounds 3 and 4 (each within the scatter of the next). At a limit, above all of these: compound 2.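

In this assay, taking the group on the shared core from methyl to butyl gives a 1.7-fold higher number from compound 3 to compound 4 (0.23 log units; within the scatter), so the two compounds cannot be told apart, and the propyl added on the saturated chain carbon bound to an aromatic carbon brings no measurable change of its own. The large step that the first methyl opened survives this lengthening, as the butyl still gives an at least 11-fold lower number from compound 2 to compound 4 (1.04 log units; beyond the scatter), which shows that among the compounds shown this place tolerates a chain well beyond methyl without giving up what the methyl gained. The size of that step carries one caution, since compound 2 stands at a limit of the assay and not at a number: the limit of > 4000 nM in this assay, at which 1 of the 4 values shown sits.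

The compounds shown do not say whether ethyl or propyl at this place would read the same as methyl and butyl, or whether a longer chain such as hexyl would stay within the scatter too. They also leave open what a chain ending in an amine or a carboxylic acid would do here.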